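The source may report more compounds than this note shows. Statements on the series, on what has been measured and on what is new or still open speak of the compounds shown alone.

The account opens with compound 1, `CO[C@@]1(CO)O[C@H](CO)[C@@H](O)[C@@H]1O`. In a functional assay, with a stated time of 30 min (on this read-out higher numbers stand for weaker inhibition and lower numbers for stronger inhibition), compound 1 reaches only the limit of the assay, > 30000 nM, so no number is known for it. Compound 2, `COC(=O)C1=CO[C@@H](O[C@@H]2O[C@H](CO)[C@@H](O)[C@H](O)[C@H]2O)C2C1[C@@H]1O[C@@H]1[C@]21O[C@@H]1O`, is the starting point of the step followed here. In this assay compound 2 likewise sits at the limit, > 30000 nM. Compound 2 therefore stands nowhere in particular among the numbers shown: both values are limits, as the limit of > 30000 nM in this assay, at which 2 of the 2 values shown sit, records, and neither compound shows measurable inhibition on this read-out. Compound 3, `COC(=O)C1=CO[C@@H](O[C@@H]2O[C@H](CO)[C@@H](O)[C@H](O)[C@H]2O)C2C1[C@@H]1O[C@@H]1[C@]21O[C@H]1O`, is the compound whose result is awaited. the two compounds have the same atoms and bonds; at least one stereo element is drawn with a configuration in one of them and without one in the other: 1 of 12 stereo elements differ; a stereocentre at a saturated ring carbon is drawn S in compound 2 and R in compound 3 No step between measured compounds is available, so nothing shown tells how a single inverted stereocentre at a saturated ring carbon moves this read-out. Since compound 2 gives only a limit, compound 3 is expected to remain there as well, and the expected step is a step that the limit leaves unreadable from compound 2 to compound 3, that is, none beyond the scatter. Compound 3 is thus estimated at 45000 nM, with a range from 12000 nM to 200000 nM, most likely reported once more only as a limit.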

Compound 3, half-maximal inhibitory concentration: > 30000 nM
Compound 3 ended at the assay's limit; the forecaster's own chance of this, stated with the estimate: 85%; the middle value does not contradict the limit.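

No step can be read from compound 2 to compound 3 in this assay, because both compounds rest at a limit of the assay and give no number: the limit of > 30000 nM in this assay, at which 3 of the 3 values shown sit. The compounds shown leave open whether the stereocentre at a saturated ring carbon, drawn S in compound 2 and R in compound 3, has any bearing on inhibition on this read-out.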